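This account rests on a few compounds, and the source may have more. Where it says the series, first, only, none or still open, it means among the compounds named here.

Series notes. The compounds share one core bearing a phenyl group and a variable substituent. Compound 1 is `Nc1cc(N)c2nc(-c3ccccc3)c(NCc3ccc(F)cc3)nc2c1`. In a functional assay on UO-31 cells (Homo sapiens) for inhibition, read by sulforhodamine B assay, with a stated time of 48 h (a higher number here means that more compound is tolerated, a lower number that less compound is tolerated), compound 1 gives < 100000 nM, a limit of the assay rather than a number. Compound 2 is `COc1ccc(CNc2nc3cc(N)cc(N)c3nc2-c2ccccc2)cc1`; in this assay compound 2 gives 72400 nM. Compound 3 is `COc1ccc(Sc2nc3cc(N)cc(N)c3nc2-c2ccccc2)cc1`. In this assay compound 3 gives < 100000 nM, again a limit and not a number. The step that the limit leaves unreadable from compound 1 to compound 2 carries methoxy in place of fluoro on an aromatic carbon; the step that the two limits leave unreadable from compound 1 to compound 3 carries (4-methoxyphenyl)sulfanyl in place of (4-fluorobenzyl)amino on an aromatic carbon. Both are left unreadable because of the limit of < 100000 nM in this assay, at which 2 of the 3 values shown sit.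

Compound 3 stands at a limit of the assay, not at a number, and compound 1 sits at the same limit. The next compound, compound 4, is `Nc1cc(N)c2nc(-c3ccccc3)c(Sc3ccc(F)cc3)nc2c1`. The change from compound 3 is fluoro in place of methoxy on an aromatic carbon. Among the measured compounds shown here, no measured step covers this exact change; the two steps that involve the methoxy and fluoro groups, both starting from compound 1, are unreadable, so no size or direction can be drawn from them. The expectation for compound 4 in this assay is therefore a step that the limit leaves unreadable from compound 3 to compound 4, most likely again reported only as a limit. Compound 4 is estimated at 90000 nM, within 30000 nM to 100000 nM.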

Compound 4, concentration lethal to 50% of the cells: < 100000 nM
Compound 4: no number, only a limit; the forecaster's own chance of this, stated with the estimate: 70%; the middle value does not contradict the limit.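

No new step can be read from compound 4, since its comparisons with compound 3 and compound 1 in this assay each join two limits, and they stay unreadable because of this: the limit of < 100000 nM in this assay, at which 3 of the 4 values shown sit.

The compounds shown leave open what size or direction, if any, the change from (4-methoxyphenyl)sulfanyl to (4-fluorophenyl)sulfanyl has in this assay.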